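Swapping a Ring Amine for an Amide in a Macrocycle

The source may report more compounds than this note shows. Statements on the series, on what has been measured and on what is new or still open speak of the compounds shown alone.

Measured compounds:
- compound 1, `CC(=O)OC/C1=C/C[C@](C)(CCC=C(C)C)/C=C/[C@@H](OC(=O)C=C(C)C)[C@](C)(OC(C)=O)/C=C/C1=O`, 4130 nM
- compound 2, `CC(C)=CCC[C@]1(C)/C=C/[C@@H](OC(=O)C=C(C)C)[C@](C)(O)/C=C/C(=O)/C(CN2CCCC2)=C\C1`, 140 nM
- compound 3, `CC(C)=CCC[C@](C)(/C=C/[C@@H](OC(=O)C=C(C)C)[C@](C)(O)/C=C/C(=O)/C=C/N1CCN(C)CC1)CC=O`, 3090 nM

These three macrocycles were tested in a functional assay on SMMC-7721 cells (Homo sapiens) for antiproliferative activity, read by MTT assay, with a stated time of 48 h; on this read-out higher numbers stand for weaker inhibition and lower numbers for stronger inhibition. Compound 2 stands out with the lowest number of the three, its nearest neighbour being compound 3 and its furthest compound 1, both separated from it by gaps beyond the usual scatter of the measurement.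

Compound 4, `CCN(CC)C(=O)/C1=C/C[C@](C)(CCC=C(C)C)/C=C/[C@@H](OC(=O)C=C(C)C)[C@](C)(O)/C=C/C1=O`, has not yet been measured. It differs from compound 2 in one place: diethylcarbamoyl in place of (pyrrolidin-1-yl)methyl on a double-bonded ring carbon. Compound 2 carries a five-membered ring holding a nitrogen, whereas compound 4 carries an open chain with a double-bonded oxygen at the same ring carbon.

Within the data shown here, no measured pair shows this exact change, so the expectation rests on the spread of the three numbers. Among the measured compounds shown here, compound 1, the only measured compound that also lacks a nitrogen attached to that ring carbon, gives 4130 nM in this assay, though it differs from compound 2 elsewhere too. For compound 4 a step toward a higher number is expected, an 11-fold higher number from compound 2 to compound 4 (1.03 log units; beyond the scatter), beyond the scatter. The estimate for compound 4 is 1500 nM, within a range from 300 nM to 6000 nM.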

Compound 4, half-maximal inhibitory concentration: 13800 nM
Beside the measured number, compound 4's estimate is 9.2-fold (0.96 log units) below it; measured number above the stated range.
By their numbers in this assay, from the lowest: compound 2; then compounds 3 and 1 (each within the scatter of the next); then compound 4.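

In this assay, among these compounds, the swap of (pyrrolidin-1-yl)methyl for diethylcarbamoyl gives a 99-fold higher number from compound 2 to compound 4 (1.99 log units; beyond the scatter) and is the first reading of this double-bonded ring carbon with the rest of the molecule held the same. The earlier compounds shown here differed from one another in more than one place, so they could not isolate this position; this pair shows that the group it carries can by itself move the number far beyond the scatter. No measurement here accounts for the size of this step.

The change removes a ring and brings in a carbonyl together, so the pair cannot say which of the two matters. An open-chain diethylaminomethyl group and a pyrrolidine-1-carbonyl group at this ring carbon would pull those two changes apart.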